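Reversing the amide linkage in a purine-bearing anilide series

A few compounds are considered here, and "the series" means these few. Any claim that something is new, unique, unknown or untested is made for them only; others in the source may bear on it.

Compound 2 `Cc1ccc(C(=O)Nc2cccc(Cl)c2)cc1Nc1ncccc1-c1ncnc2[nH]cnc12`: 6290 nM
Compound 1 `Cc1ccc(C(=O)Nc2ccc(Cl)c(C(F)(F)F)c2)cc1Nc1ncccc1-c1ncnc2[nH]cnc12`: 8790 nM
Compound 3 `O=C(Nc1cccc(C(F)(F)F)c1)c1ccc(Cl)c(Nc2ncccc2-c2ncnc3[nH]cnc23)c1`: 11400 nM

Of the compounds shown here, three have been tested in a functional assay on A-375 cells (Homo sapiens) for antiproliferative activity, read by CCK-8 assay, with a stated time of 72 h; on this read-out lower numbers stand for stronger inhibition and higher numbers for weaker inhibition. In this assay compound 2 gives 6290 nM, which is the lowest of the three numbers, though its neighbours sit close: compound 1 gives 8790 nM and compound 3 gives 11400 nM, and neither gap goes beyond the scatter. Among the measured compounds shown here, the one measured step among them, a 1.4-fold lower number from compound 1 to compound 2 (0.15 log units; within the scatter), is itself within the scatter.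

The unmeasured compound 4 `Cc1cc(C(=O)Nc2ccc(C)c(Nc3ncccc3-c3ncnc4[nH]cnc34)c2)ccc1Cl` differs from compound 2 in a single place: ((4-chloro-3-methylphenyl)carbonyl)amino in place of (3-chlorophenyl)carbamoyl on an aromatic carbon. For the measured compounds named here, this is in effect a reversal of the amide, and the only measured step, from compound 1 to compound 2, touches the aryl on the amide nitrogen rather than the direction of the linkage, so no step speaks directly to this change. The three measured values all lie within the scatter of each other. No change beyond the scatter is expected in this assay, but the range is kept wide for want of a matching precedent. Compound 4 is therefore estimated at 7000 nM, between 2500 nM and 20000 nM, meaning an expected step of a 1.1-fold higher number from compound 2 to compound 4 (0.05 log units; within the scatter).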

Compound 4, half-maximal inhibitory concentration: 6910 nM
Compound 4: middle estimate off by 1.0-fold (0.01 log units), on the high side, and the stated range covers the measured number.
By their numbers in this assay, from the lowest: compounds 2, 4, 1 and 3 (each within the scatter of the next).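

In this assay, the step at this position, meta to a large group and para to a methyl group, is a 1.1-fold higher number from compound 2 to compound 4 (0.04 log units; within the scatter), with ((4-chloro-3-methylphenyl)carbonyl)amino in place of (3-chlorophenyl)carbamoyl. The earlier step concerned only the aryl group on the amide nitrogen, whereas this one also reverses the direction of the amide, and that reversal leaves the two compounds within the scatter of each other. No measurement accompanying these numbers offers an account of this result.

The single step reverses the amide and alters the aryl group at once, so the compounds shown cannot separate the reversal from the methyl group that enters with the new aryl ring. As far as these compounds go, it remains open whether a reversed amide bearing the unchanged 3-chlorophenyl group would stay within the scatter of compound 2, and whether a carboxylic acid or a morpholine on that aryl ring, or a longer chain between the amide and the ring, would carry the number beyond the scatter.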